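Shrinking the Ring on a Sulfonamide Side Chain

The source may report more compounds than this note shows. Statements on the series, on what has been measured and on what is new or still open speak of the compounds shown alone.

Compound 3 `NC(=O)[C@@H](CCC(F)(F)F)N(C[C@H]1CCCOC1)S(=O)(=O)c1ccc(Cl)cc1` gives 18.2 10^-6 cm/s in an ADME assay on MDCKII-LE cells (Canis lupus familiaris) for permeability, read by transwell migration, in the apical to basolateral direction; a higher number here means that the compound crosses the layer faster, a lower number that the compound crosses the layer more slowly. Compound 1 `CC1(C)C[C@@H](CN([C@H](CCC(F)(F)F)C(N)=O)S(=O)(=O)c2ccc(Cl)cc2)O1` gives 14.9 10^-6 cm/s and compound 2 `CC1(C)C[C@H](CN([C@H](CCC(F)(F)F)C(N)=O)S(=O)(=O)c2ccc(Cl)cc2)O1` gives 18.1 10^-6 cm/s; the steps of a 1.2-fold higher number from compound 1 to compound 3 (0.09 log units; within the scatter) and a 1.0-fold higher number from compound 2 to compound 3 (0.00 log units; within the scatter) leave compound 3 no more than level with its two neighbours. The step of a 1.2-fold higher number from compound 1 to compound 2 (0.08 log units; within the scatter) is likewise small, and (the fact that compounds 1 and 2 differ only in the configuration as drawn). Compound 4 `NC(=O)[C@@H](CCC(F)(F)F)N(C[C@H]1CCO1)S(=O)(=O)c1ccc(Cl)cc1` carries the change (oxetan-2-yl in place of oxan-3-yl on a saturated chain carbon bound to a sulfonamide nitrogen). Among the compounds with values here, the only steps that bear on it, those from a dimethyl oxetane to an oxane, stayed within the scatter, so no step beyond the scatter is expected here: a 1.2-fold lower number from compound 3 to compound 4 (0.08 log units; within the scatter). Compound 4 is therefore expected to give about 15 10^-6 cm/s in this assay, between 8 10^-6 cm/s and 28 10^-6 cm/s.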

Compound 4, apparent permeability: 28.7 10^-6 cm/s
Compound 4: middle estimate off by 1.9-fold (0.28 log units), on the low side, outside the stated range (above it).
By their numbers in this assay, from the lowest: compounds 1, 2, 3 and 4 (each within the scatter of the next).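

Going from oxan-3-yl to oxetan-2-yl on a saturated chain carbon bound to a sulfonamide nitrogen stays within the scatter in this assay: a 1.6-fold higher number from compound 3 to compound 4 (0.20 log units; within the scatter). Losing the dimethyl substitution on the oxetane reads the same way, with a 1.6-fold higher number from compound 2 to compound 4 (0.20 log units; within the scatter) and a 1.9-fold higher number from compound 1 to compound 4 (0.28 log units; within the scatter), so neither ring size nor those methyl groups moves this number beyond the scatter in these compounds. Nothing measured here offers an explanation for these steps. All four compounds carry a saturated ring with one oxygen in this place. From the compounds shown here alone, how an amine or a carboxylic acid there would read in this assay remains open.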